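From 3,5-difluorophenyl to 3,5-dibromophenyl on an oxygen

A few compounds are considered here, and "the series" means these few. Any claim that something is new, unique, unknown or untested is made for them only; others in the source may bear on it.

In a functional assay on HT-29 cells (Homo sapiens) for antiproliferative activity, read by sulforhodamine B assay, with a stated time of 48 h (a higher number here means a weaker inhibitor, a lower number a stronger inhibitor), compound 1 `CCCCN1CCN(c2ccc(S(=O)(=O)Oc3cccc(Br)c3)cc2)C1=O` gives 16000 nM. Compound 2 `CCCCN1CCN(c2ccc(S(=O)(=O)Oc3cc(F)cc(F)c3)cc2)C1=O` reads > 100000 nM, which is a limit of the assay and not a number. Compound 2 therefore has only a bound on the scale, as this note records: the limit of > 100000 nM in this assay, at which 1 of the 2 values shown sits.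

Compound 3 `CCCCN1CCN(c2ccc(S(=O)(=O)Oc3cc(Br)cc(Br)c3)cc2)C1=O` carries 3,5-dibromophenyl in place of 3,5-difluorophenyl on an oxygen, the same oxygen on the sulfonyl sulfur: 3,5-dibromophenyl in place of 3,5-difluorophenyl on an oxygen.

Among the compounds with values here, one measured step bears on this change: an at least 6.2-fold higher number from compound 1 to compound 2 (0.79 log units; beyond the scatter), with 3,5-difluorophenyl in place of 3-bromophenyl. That step lies beyond the scatter, and its size is only a bound. The change to compound 3 restores bromine, so a lower number is expected in this assay, in the direction of compound 1 at 16000 nM. Within the data shown here, no measured step goes from 3-bromophenyl to 3,5-dibromophenyl, so the range stays wide.

The expected step is an at least 8.3-fold lower number from compound 2 to compound 3 (0.92 log units; beyond the scatter). For compound 3 the estimated value is 12000 nM, with an expected range of 3000 nM to 60000 nM.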

Compound 3, half-maximal inhibitory concentration: 43000 nM
Compound 3: middle estimate off by 3.6-fold (0.55 log units), on the low side, and the stated range covers the measured number.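

Within the data shown here, with the oxygen on the sulfonyl sulfur held constant, this assay gives an at least 2.3-fold lower number from compound 2 to compound 3 (0.36 log units; beyond the scatter) for 3,5-dibromophenyl in place of 3,5-difluorophenyl, the first comparison of the two halogens on a matched ring. Among these compounds, compound 2 stands at a limit of the assay and not at a number, so this step is a bound only: the limit of > 100000 nM in this assay, at which 1 of the 3 values shown sits. The added bromo does not improve on the single bromo of compound 1, as bromo in place of hydrogen on an aromatic carbon gives a 2.7-fold higher number from compound 1 to compound 3 (0.43 log units; beyond the scatter), so within these three compounds 3-bromophenyl gives the lowest number, and 3,5-dibromophenyl falls short of it while still reading below the limit of the difluoro compound.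

Still open, from the compounds shown here alone, is whether the effect of the added bromo belongs to bromine itself or would appear with any second group on this ring, which a 3-chloro-5-bromophenyl or 3-bromo-5-methoxyphenyl group would help to separate. The compounds shown also leave open how 3-fluorophenyl or 3,5-dichlorophenyl would read on the same oxygen, and so whether the gap between the halogens is graded or abrupt.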